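Series notes: from compound 1 to compound 3

A few compounds are considered here, and "the series" means these few. Any claim that something is new, unique, unknown or untested is made for them only; others in the source may bear on it.

compound 1 `Nc1ccccc1NC(=O)c1ccc(CSC(=S)N2CCN(c3ccc(Cl)cc3)CC2)cc1` — 51.2%
compound 2 `CN(Cc1ccncc1)C(=S)SCc1ccc(C(=O)Nc2ccccc2N)cc1` — 29.5%

Within the data shown here, in a functional assay on HeLa cells (Homo sapiens) for antiproliferative activity, read by CCK-8 assay, with a stated time of 72 h, tested at 2 uM (on this read-out higher numbers stand for a stronger effect at the one concentration tested and lower numbers for a weaker effect), compound 1 gives 51.2%, the higher of the two numbers so far; compound 2 gives 29.5%, lower by more than the usual scatter. Compound 3 `Nc1ccccc1NC(=O)c1ccc(CSC(=S)N2CCN(c3ncccn3)CC2)cc1` has not yet been measured. It differs from compound 1 in one place: pyrimidin-2-yl in place of 4-chlorophenyl on an amine nitrogen in a ring. Among the measured compounds shown here, no measured pair shows this change, so the size of its effect is unknown from the data. For compound 3 a modest downward step in this assay, or none beyond the scatter, is expected, estimated as a number 9.2 percentage points lower from compound 1 to compound 3 (within the scatter). Compound 3 is thus expected to give about 42%, in the range 25% to 60%.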

Compound 3, a percentage reported as inhibition, at one concentration (the size of the read-out at that concentration, not a potency): 52.2%
Beside the measured number, compound 3's estimate is 10.2 percentage points below it, and the stated range covers the measured number.
By their numbers in this assay, from the lowest: compound 2; then compounds 1 and 3 (each within the scatter of the next).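

In this assay the step of a number 1 percentage points higher from compound 1 to compound 3 (within the scatter) shows that pyrimidin-2-yl and 4-chlorophenyl on this amine nitrogen in a ring cannot be told apart. At this position, one six-membered aromatic ring of carbon only and one with 2 hetero atoms therefore serve alike at the one concentration tested. No measurement at hand bears on the reason for this result. Open, on these data alone, is how a non-aromatic group on this nitrogen, such as cyclohexyl or a plain methyl, would read. Also open, as far as these compounds go, is whether the two aromatic groups stay level on other cell lines.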